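Working notes: trifluoromethyl for bromo in an antiproliferative series

A few compounds are considered here, and "the series" means these few. Any claim that something is new, unique, unknown or untested is made for them only; others in the source may bear on it.

Measured compounds in a functional assay on MCF7 cells (Homo sapiens) for antiproliferative activity, read by MTT assay, with a stated time of 24 h; a lower number here means a stronger inhibitor, a higher number a weaker inhibitor:
compound 1 `O=S(=O)(c1ccc(Br)cc1)n1c(-c2cn(-c3ccccc3)nc2-c2ccc(F)cc2)nc2ccccc21` gives 2630 nM
compound 2 `O=S(=O)(c1ccc(C(F)(F)F)cc1)n1c(-c2cn(-c3ccccc3)nc2-c2ccc(F)cc2)nc2ccccc21` gives 1580 nM
compound 3 `O=S(=O)(c1ccc(Br)cc1)n1c(-c2cn(-c3ccccc3)nc2-c2ccc(C(F)(F)F)cc2)nc2ccccc21` gives 2470 nM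

The cores of compound 1 and compound 3 differ by trifluoromethyl in place of fluoro on an aromatic carbon; the step is a 1.1-fold lower number from compound 1 to compound 3 (0.03 log units; within the scatter). Within the core of compound 1, the change to compound 2 is trifluoromethyl in place of bromo on an aromatic carbon, and it gave a 1.7-fold lower number from compound 1 to compound 2 (0.22 log units; within the scatter). Compound 4 `O=S(=O)(c1ccc(C(F)(F)F)cc1)n1c(-c2cn(-c3ccccc3)nc2-c2ccc(C(F)(F)F)cc2)nc2ccccc21` is not yet measured. It differs from compound 3 by trifluoromethyl in place of bromo on an aromatic carbon, the same change made from compound 1 to compound 2, at the same place. Beside that earlier step, the expected step is a 1.5-fold lower number from compound 3 to compound 4 (0.19 log units; within the scatter); this expectation rests on a 1.7-fold lower number from compound 1 to compound 2 (0.22 log units; within the scatter) and on the value of compound 3, 2470 nM. Compound 4 is therefore estimated at 1600 nM in this assay, with the expected range running from 800 nM to 3500 nM.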

Compound 4, half-maximal inhibitory concentration: 1240 nM
The estimate for compound 4 lay 1.3-fold (0.11 log units) above the measured number; low and high end bracket the measured number.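

In this assay, trifluoromethyl in place of bromo gave a 2.0-fold lower number from compound 3 to compound 4 (0.30 log units; within the scatter), and this step agrees with the one made on the core of compound 1: the same change on two cores in this assay, a 1.7-fold lower number (0.22 log units; within the scatter) from compound 1 to compound 2 and a 2.0-fold lower number (0.30 log units; within the scatter) from compound 3 to compound 4, 1.2-fold (0.08 log units) apart, within the scatter of two such steps. Trifluoromethyl in place of fluoro gave a 1.3-fold lower number from compound 2 to compound 4 (0.11 log units; within the scatter), which likewise agrees with its earlier step: the same change on two cores in this assay, a 1.1-fold lower number (0.03 log units; within the scatter) from compound 1 to compound 3 and a 1.3-fold lower number (0.11 log units; within the scatter) from compound 2 to compound 4, 1.2-fold (0.08 log units) apart, within the scatter of two such steps. Among the compounds shown here, every one of these steps lies within the scatter, and the agreement therefore shows only that neither change moved the number measurably on these two cores; it does not show a real gain that carries over, nor does it speak for other cores.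

Still open, as far as these compounds go, is how an amine, a carboxylic acid or a longer chain at the place of bromo or trifluoromethyl would read in this assay, and whether any such group would move the number beyond the scatter.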